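Swapping the Pyridyl for a Trifluoromethylphenyl on the Triazole

The source may hold more compounds than are shown below. What is called first, only, known or untested is meant among the compounds shown, and "the series" means these compounds.

Measured compounds:
compound 1 `C=C1C[C@]23C[C@@]1(O)CC[C@H]2c1ccc(O)c(C)c1[C@@H]3Cn1cc(-c2ccccn2)nn1` — > 20000 nM
compound 2 `Cc1ccc(S(=O)(=O)Oc2ccc3c(c2C)[C@H](Cn2cc(-c4ccccc4)nn2)[C@@]24CC(=O)[C@@](C)(CC[C@@H]32)C4)cc1` — > 20000 nM
compound 3 `C=C1C(=O)[C@]23C[C@@]1(O)CC[C@H]2c1ccc(OS(=O)(=O)c2ccc(C)cc2)c(C)c1[C@@H]3Cn1cc(-c2ccc(Cl)cc2)nn1` — 1870 nM

Of the compounds shown here, three sharing one core have been tested in a functional assay on A549 cells (Homo sapiens) for cytotoxicity, read by MTT assay, with a stated time of 4 days; on this read-out higher numbers stand for weaker inhibition and lower numbers for stronger inhibition. For compound 1 the result is not a number but a limit, > 20000 nM. Compound 2 likewise only reaches a limit, > 20000 nM. Compound 3, which carries a 4-chlorophenyl on the triazole together with a tosylate and a ketone on the core, gives 1870 nM. Compound 1 therefore stands at the weak end of what has been seen, at the limit of > 20000 nM in this assay, at which 2 of the 3 values shown sit.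

Compound 4 `C=C1C[C@]23C[C@@]1(O)CC[C@H]2c1ccc(O)c(C)c1[C@@H]3Cn1cc(-c2ccc(C(F)(F)F)cc2)nn1` differs from compound 1 by one change: 4-(trifluoromethyl)phenyl in place of pyridin-2-yl on an aromatic carbon. For the measured compounds named here, no pair of measured compounds differs in only one place, so this step has no measured counterpart. Since the aryl variation in compound 2 left it at a limit, the expected step from compound 1 to compound 4 in this assay is none beyond the scatter, written as an at least 1.1-fold lower number from compound 1 to compound 4 (0.04 log units; that floor lies within the scatter). Compound 4 is expected to give about 18000 nM, somewhere between 5000 nM and 60000 nM, most likely again reported only as a limit.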

Compound 4, half-maximal inhibitory concentration: 10400 nM
Compound 4: the middle estimate sits 1.7-fold (0.24 log units) above what was measured, and the stated range covers the measured number.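

Putting 4-(trifluoromethyl)phenyl in place of pyridin-2-yl, on an aromatic carbon of a five-membered aromatic ring with 3 nitrogen, gives an at least 1.9-fold lower number from compound 1 to compound 4 (0.28 log units; that floor lies within the scatter) in this assay. Compound 1 stays a limit rather than a number: the limit of > 20000 nM in this assay, at which 2 of the 4 values shown sit. The change at this position therefore takes the core of compound 1 from a limit to a value that can be read as a number, but the true size of the step cannot be read, and its floor alone does not clear the usual scatter.

From the compounds shown here alone, it remains open whether the trifluoromethyl group or the carbon-only ring matters more for this result. A plain phenyl, a 4-chlorophenyl or a phenyl carrying an amine or a carboxylic acid at this position on the core of compound 1 would help to separate the two.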